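The compounds below may be only part of what the source reports. "The series", "measured", "known", "first", "only" and "open" are said of these compounds alone.

The compounds measured so far, with their values in a functional assay on BE(2)-C cells (Homo sapiens) for inhibition, read by MTT assay, with a stated time of 72 h; a higher number here means a weaker inhibitor of growth, a lower number a stronger inhibitor of growth:

Compound 1 `COc1ccc(CNCCCNS(=O)(=O)c2cc(C(F)(F)F)cc(C(F)(F)F)c2)cc1OC` gives 3600 nM in this assay.
Compound 2 `O=S(=O)(NCCCNCc1ccc(-c2ccccc2)cc1)c1cc(C(F)(F)F)cc(C(F)(F)F)c1` gives 2600 nM in this assay.

Compound 1 and compound 2 share the same core and differ only in the benzyl part. The two numbers sit close together, and the gap between them is within the usual scatter of repeated measurements, so neither compound can be called the stronger or weaker grower inhibitor on this evidence. Compound 1 is therefore the reference point for the next step without any ranking attached to it.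

Compound 3 `COc1cccc(CNCCCNS(=O)(=O)c2cc(C(F)(F)F)cc(C(F)(F)F)c2)c1` is not yet measured. Compared with compound 1, the change is hydrogen in place of methoxy on an aromatic carbon. Within the data shown here, no pair of measured compounds with a single difference of this kind exists, so the size of the step cannot be read from the data. Given that the larger change from compound 1 to compound 2 stayed within the scatter, the step from compound 1 to compound 3 in this assay is expected to be small, with no clear direction beyond the scatter, as a 1.0-fold lower number from compound 1 to compound 3 (0.01 log units; within the scatter). Compound 3 is expected to give about 3500 nM in this assay, within a range from 1500 nM to 8000 nM.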

Compound 3, concentration for 50% growth inhibition: 4500 nM
The estimate for compound 3 lay 1.3-fold (0.11 log units) below the measured number; the measured number falls inside the stated range.
By their numbers in this assay, from the lowest: compounds 2, 1 and 3 (each within the scatter of the next).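

Going from 3,4-dimethoxybenzyl to 3-methoxybenzyl, with hydrogen in place of methoxy, gives the first step in this assay that turns on a single substituent: a 1.3-fold higher number from compound 1 to compound 3 (0.10 log units; within the scatter). Among these compounds, at this aromatic carbon, ortho to a methoxy group and para to a large group, the methoxy can therefore be replaced by hydrogen without a change that this assay can separate from the scatter, something the earlier compounds, which offered no such single-substituent comparison, could not show. Nothing available explains this result or gives a measured property of the methoxy group at this position.

The compounds shown leave open whether the remaining methoxy of the 3-methoxybenzyl group can also give way to hydrogen, and whether a fluorine, a chlorine or a hydroxyl group at the carbon that now carries hydrogen would move the number beyond the scatter. They also leave open what a longer chain between the sulfonamide and the benzyl amine would do, or a nitrile in place of a trifluoromethyl group on the shared core.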